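Swapping the sulfonyl aryl group: does the clearance number move?

The compounds below may be only part of what the source reports. "The series", "measured", "known", "first", "only" and "open" are said of these compounds alone.

Three compounds sharing one core differ only in the aryl group on a sulfonyl sulfur. Compound 1 `COc1cccc(-c2c(S(=O)(=O)c3ccc(C)c(F)c3)cnc3c(F)cccc23)c1` gives 4.02 mL/min in an ADME assay on microsomes from liver (Homo sapiens) for metabolic stability, tested at 2.5 uM; on this read-out higher numbers stand for fast clearance and lower numbers for slow clearance. Compound 2 `COc1cccc(-c2c(S(=O)(=O)c3cc(F)cc(F)c3)cnc3c(F)cccc23)c1` gives 2.76 mL/min in this assay, and compound 3 `COc1cccc(-c2c(S(=O)(=O)c3cc(Cl)cc(Cl)c3)cnc3c(F)cccc23)c1` gives 2.31 mL/min. The three numbers lie close together: the change a 1.5-fold lower number from compound 1 to compound 2 (0.16 log units; within the scatter), the change a 1.7-fold lower number from compound 1 to compound 3 (0.24 log units; within the scatter) and the change a 1.2-fold lower number from compound 2 to compound 3 (0.08 log units; within the scatter) all stay inside the spread that repeated measurements of this kind show. Compound 3 sits at the low end of the three, but the gaps to compound 1 and compound 2 are within that scatter, so no real ordering can be read from them.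

Compound 4 `COc1cccc(-c2c(S(=O)(=O)c3ccc(F)cc3)cnc3c(F)cccc23)c1` has not yet been measured in this assay. Its structural difference from compound 3 is 4-fluorophenyl in place of 3,5-dichlorophenyl on a sulfonyl sulfur. Every step already seen is a swap of the aryl group on the same sulfonyl sulfur, and each of those steps stayed within the scatter. On that basis the expected step is a 1.3-fold higher number from compound 3 to compound 4 (0.11 log units; within the scatter), with no movement beyond the scatter anticipated. Compound 4 is therefore estimated to give 3 mL/min in this assay, with a likely range from 1.6 mL/min to 5.5 mL/min.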

Compound 4, intrinsic clearance in a liver preparation (reported as CLH), per the amount of preparation that the assay uses: 2.23 mL/min
For compound 4 the middle estimate is 1.3-fold (0.13 log units) above the measured one, and the stated range covers the measured number.
By their numbers in this assay, from the lowest: compounds 4, 3, 2 and 1 (each within the scatter of the next).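

With 4-fluorophenyl on the sulfonyl sulfur, the aryl group now carries 1 fluorine and no chlorine or methyl, yet the clearance number in this assay shows no real movement against any earlier compound. The comparison with the 3,5-dichlorophenyl compound gives the smallest step (a 1.0-fold lower number from compound 3 to compound 4 (0.02 log units; within the scatter)), the comparison with the 3,5-difluorophenyl compound gives a similar result (a 1.2-fold lower number from compound 2 to compound 4 (0.09 log units; within the scatter)), and the largest step, from the 3-fluoro-4-methylphenyl compound, also stays within the scatter (a 1.8-fold lower number from compound 1 to compound 4 (0.26 log units; within the scatter)). Across these four aryl groups the read-out therefore stays flat, and nothing available explains why.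

From the compounds shown here alone, all four groups are substituted phenyl rings, so it remains open whether an amine, a carboxylic acid or a saturated ring such as cyclohexyl on the sulfonyl sulfur would leave the number just as unmoved. Every step shown also sits at this one place, and what a change elsewhere on the shared core would do to clearance remains open.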